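The source may report more compounds than this note shows. Statements on the series, on what has been measured and on what is new or still open speak of the compounds shown alone.

Compound 1 `Cc1cccc(NC(=O)CN2CCC(c3ccccc3C#N)CC2)c1` sits at the low end of the three numbers measured in a functional assay on HEK293 cells for agonist activity at D(4) dopamine receptor (Homo sapiens), read by FLIPR (a higher number here means that more compound is needed for the effect, a lower number that less compound is needed), where compound 1 gives 8 nM. Compound 2 `Cc1cccc(C(=O)NCN2CCC(c3ccccn3)CC2)c1` is close: in this assay compound 2 gives 9 nM, a value within the usual scatter of that of compound 1, so the two cannot be ranked against each other. Compound 3 `Cc1ccc(C(=O)NCN2CCC(c3cccc[n+]3[O-])CC2)cc1C` stands further off; in this assay compound 3 gives 38 nM, a number that lies beyond the scatter above compound 1. Compound 4 `Cc1cccc(NC(=O)CN2CCC(c3ccc(O)cc3)CC2)c1` has not yet been measured. It differs from compound 1 in one place (4-hydroxyphenyl in place of 2-cyanophenyl on a saturated ring carbon). For the measured compounds named here, no measured pair isolates this change, so the expectation rests on the structural change itself and on compound 1 as the anchor with its 8 nM. A modest move toward a higher number is expected, a 3.8-fold higher number from compound 1 to compound 4 (0.57 log units; beyond the scatter), beyond the scatter but not large. Compound 4 is therefore estimated to give 30 nM in this assay, with a range from 8 nM to 120 nM.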

Compound 4, half-maximal effective concentration: 70 nM
The estimate for compound 4 lay 2.3-fold (0.37 log units) below the measured number; the range from low to high includes it.
By their numbers in this assay, from the lowest: compounds 1 and 2 (each within the scatter of the next); then compounds 3 and 4 (each within the scatter of the next).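

In this assay, placing 4-hydroxyphenyl in place of 2-cyanophenyl on the saturated ring carbon gives an 8.8-fold higher number from compound 1 to compound 4 (0.94 log units; beyond the scatter) and so shows that this position is sensitive to the group it carries. No earlier pair could show this, since this is the first step among the compounds shown that isolates a change in one place. Nothing at hand accounts for the size of this step.

The compounds shown do not separate the departure of the nitrile from the arrival of the hydroxyl group, nor the effect of where each sits on the aromatic ring. Going by these compounds, whether a plain phenyl or a methoxyphenyl group at this position would give a number closer to that of compound 1 or that of compound 4 remains open.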